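The source may hold more compounds than are shown below. What is called first, only, known or untested is meant among the compounds shown, and "the series" means these compounds.

Measured so far in a functional assay on MCF7 cells (Homo sapiens) for antiproliferative activity; a lower number here means a stronger inhibitor, a higher number a weaker inhibitor:
Compound 1 `CCCCCn1c(Cc2cc(OC)c(OC)c(OC)c2)nc2c(N)nc(F)nc21` gives 36300 nM.
Compound 2 `COc1cc(Cc2nc3c(N)ncnc3n2CC(C)C)cc(OC)c1OC` gives 97700 nM.

Compound 2 stands with the higher of the two numbers, so it is the weaker inhibitor of the pair, and its gap to compound 1 lies beyond the usual scatter. Compound 3 `C=CCCn1c(Cc2cc(OC)c(OC)c(OC)c2)nc2c(N)ncnc21` has not yet been measured. It differs from compound 2 in one place: allyl in place of isopropyl on a saturated chain carbon bound to an aromatic nitrogen. Among the compounds with values here, no measured pair shows this change, so the expectation rests on compound 2 alone. The step of a 1.6-fold lower number from compound 2 to compound 3 (0.21 log units; within the scatter) is expected to be small, toward a lower number, barely beyond the scatter. Compound 3 is therefore estimated at 60000 nM, within a range from 20000 nM to 200000 nM.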

Compound 3, half-maximal inhibitory concentration: 40700 nM
Estimate against measurement, compound 3: 1.5-fold (0.17 log units) above, within the range that was stated.
By their numbers in this assay, from the lowest: compounds 1 and 3 (each within the scatter of the next); then compound 2.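

Replacing isopropyl with allyl on the saturated chain carbon bound to an aromatic nitrogen gives a 2.4-fold lower number from compound 2 to compound 3 (0.38 log units; beyond the scatter) in this assay, a modest step. This position therefore responds to a change that keeps the same three carbons and adds one double bond, with no ring, hydrogen-bond donor or acceptor, or charge entering. No evidence here explains the step.

A plain butyl chain would help show whether the double bond or the unbranched chain matters. Going by these compounds, how an amine or a carboxylic acid would read at this place also stays open.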